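This account rests on a few compounds, and the source may have more. Where it says the series, first, only, none or still open, it means among the compounds named here.

Measured so far:
Compound 1, `COc1ccc(-c2cnc3nc(N)nc(N4CCN(C(=O)NCc5ccc(F)cc5)CC4)c3n2)cc1OC`, in a functional assay on cells (T-cell, Homo sapiens) for inhibition; a lower number here means a stronger inhibitor, a higher number a weaker inhibitor: 37 nM.
Compound 2, `CC(C)Oc1nc(N)nc2ncc(-c3ccc(F)c(F)c3)nc12`, in this assay: 10000 nM.
Compound 3, `COc1ccc(-c2cnc3nc(N)nc(OC(C)C)c3n2)cc1`, in this assay: > 10000 nM, which is a limit of the assay and not a number.

Compound 3 therefore stands only at a limit; among the three values shown it is the one sitting at the limit of > 10000 nM in this assay, at which 1 of the 3 values shown sits. Compound 1 and compound 2 both give numbers, and compound 1 gives the lower of the two. Going by the values given here, no step between two measured compounds that differ in one place is available, so the move from compound 3 to compound 4, `CC(C)Oc1nc(N)nc2ncc(-c3ccc(C#N)cc3)nc12`, has no measured counterpart in this set.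

The change is cyano in place of methoxy on an aromatic carbon. Compound 4 keeps everything else of compound 3 unchanged.

With compound 3 sitting at a limit, the step in this assay from compound 3 to compound 4 is expected to be small, of uncertain direction, and probably not beyond the usual scatter, an at least 1.2-fold lower number from compound 3 to compound 4 (0.09 log units; that floor lies within the scatter). Compound 4 is expected to give about 8000 nM, in the range 2000 nM to 30000 nM, with a real chance that only a limit is reported again.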

Compound 4, half-maximal inhibitory concentration: > 10000 nM
Compound 4 gave a limit, no number (the forecaster's own chance of this, stated with the estimate: 50%); at least 1.2-fold (0.09 log units) between middle value and limit.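

Going by these compounds alone, compound 3 and compound 4 both stand only at a limit in this assay, so no step between them can be read: the limit of > 10000 nM in this assay, at which 2 of the 4 values shown sit.

The compounds shown leave open whether cyano in place of methoxy on this aromatic carbon changes inhibition in this assay at all.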